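This account rests on a few compounds, and the source may have more. Where it says the series, first, only, none or still open, it means among the compounds named here.

Compound 1, with the structure `COc1ccc2oc(=O)cc(CO/N=C(\C)C(C)=O)c2c1`, is a coumarin-type ether carrying a methoxy group on its aromatic ring and an oxime side chain. In a physicochemical assay for acid dissociation, using potentiometric titration, compound 1 gives 5.8. Among the compounds with values here, the only other measured compound, compound 2 with the structure `CC(=O)/C(C)=N/OCc1cc(=O)oc2cc(C)cc(C)c12`, carries two methyl groups on the same ring; in this assay compound 2 gives 5.5. Within the data shown here, these two values lie within the usual scatter of repeated measurements, so the data do not separate compound 1 from compound 2, and no step between them can be counted.

Compound 3, with the structure `CC(=O)/C(C)=N/OCc1cc(=O)oc2ccc(C)cc12`, has not yet been measured in this assay. It differs from compound 1 in one place: methyl in place of methoxy on an aromatic carbon. Among the measured compounds shown here, since no measured pair shows what this exchange does to the acid dissociation constant, the expectation rests on compound 2 alone, whose methyl-bearing ring gave a value close to that of compound 1. Compound 3 is therefore expected to give 5.6, between 5.2 and 6. The step this estimate means, a number 0.20 log units lower from compound 1 to compound 3 (within the scatter), is expected to stay within the scatter rather than point in any clear direction.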

Compound 3, acid dissociation constant: 5.7
For compound 3 the middle estimate is 0.10 log units below the measured one, within the range that was stated.
By their numbers in this assay, from the lowest: compounds 2, 3 and 1 (each within the scatter of the next).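

In this assay, the exchange of methoxy for methyl on an aromatic carbon, meta to a fused ring and para to a fused ring, now has a directly measured step, a number 0.10 log units lower from compound 1 to compound 3 (within the scatter). Within the data shown here, this is the first pair that differs in one place only, so the comparison no longer has to lean on compound 2, which carries two methyl groups on that ring. At this position, going from methoxy, with 2 heavy atoms and 1 hydrogen-bond acceptor, to methyl, with 1 heavy atom and 0 hydrogen-bond acceptors, gives no difference that this measurement can separate, and nothing available speaks to the reason for this result.

Methoxy and methyl both carry no net charge, so it remains open whether an amine or a carboxylic acid at this position would give a step beyond the scatter. From the compounds shown here alone, it also remains open whether a longer chain such as butoxy would behave as these two groups do, and whether the same exchange elsewhere on the shared core would give a similar result.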